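This account rests on a few compounds, and the source may have more. Where it says the series, first, only, none or still open, it means among the compounds named here.

Measured in an ADME assay on MT4 cells (Homo sapiens) for cytotoxicity, read by MTT assay; on this read-out lower numbers stand for higher toxicity in this test and higher numbers for lower toxicity in this test:
- Compound 1 `O=C1c2ccccc2C(=O)N1CCOC(=S)N(C(=O)c1ccccc1[N+](=O)[O-])c1ccc(Cl)cc1`: 21000 nM
- Compound 2 `Cc1ccc(C(=O)N(C(=S)OCCN2C(=O)c3ccccc3C2=O)c2ccc(Cl)cc2)cc1`: > 100000 nM

Compound 2 stands at a limit of this assay, not at a number. Compound 3 `O=C1c2ccccc2C(=O)N1CCOC(=S)N(C(=O)c1ccc(C(F)(F)F)cc1)c1ccc(Cl)cc1` differs from it by trifluoromethyl in place of methyl on an aromatic carbon, with trifluoromethyl in place of methyl on an aromatic carbon. Going by the values given here, the only measured step, an at least 4.7-fold higher number from compound 1 to compound 2 (0.67 log units; beyond the scatter), changes the same aromatic group on the carbonyl carbon, but it ends at the limit, so its full size is unknown. A small downward shift or none is expected, and the estimated change is an at least 1.4-fold lower number from compound 2 to compound 3 (0.15 log units; that floor lies within the scatter). For compound 3 the expected value is 70000 nM, with an estimated range of 25000 nM to 160000 nM.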

Compound 3, half-maximal cytotoxic concentration: 10000 nM
Estimate against measurement, compound 3: 7.0-fold (0.85 log units) above; the measured number lies below the stated range.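

In this assay, the group on this aromatic carbon clearly matters: trifluoromethyl in place of methyl gives an at least 10-fold lower number from compound 2 to compound 3 (1.00 log units; beyond the scatter). Compound 2 stands at a limit, not at a number: the limit of > 100000 nM in this assay, at which 1 of the 3 values shown sits. Replacing 2-nitrophenyl on the carbonyl carbon does not raise the number in every case, since 4-(trifluoromethyl)phenyl gives a 2.1-fold lower number from compound 1 to compound 3 (0.32 log units; beyond the scatter), and compound 3 thus goes against the rise seen with 4-methylphenyl.

The compounds shown leave open how a methoxy, a nitrile or an amine in the same place would read out. They also leave open whether this change would give a similar step with another group in place of the 2-nitrophenyl or 4-chlorophenyl parts of the shared core.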